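Lactam for benzamide on the triazolopyrazine core

A few compounds are considered here, and "the series" means these few. Any claim that something is new, unique, unknown or untested is made for them only; others in the source may bear on it.

Compound 2 `O=C(Nc1cnc(NCc2c(F)ccc3c2CCO3)n2cnnc12)c1ccccc1` is one of three measured members of the series. In a physicochemical assay for lipophilicity, using the shake flask method, in phosphate buffer, measured as octanol-water partition, with a stated time of 30 min, at pH 7.4 (on this read-out higher numbers stand for higher lipophilicity and lower numbers for lower lipophilicity), compound 2 gives 3, level at the digits shown with compound 1 `Cc1cc(-c2cnc(NCc3c(F)ccc4c3CCO4)c3cn[nH]c(=O)c23)n(C)n1`, which gives 3; together these are the highest of the three numbers. Compound 3 `CNC(=O)c1ncc(-c2cnc(NCc3c(F)ccc4c3CCO4)c3cn[nH]c(=O)c23)n1C` gives 2.5, the furthest of the three from compound 2 and lower than it. Going by the values given here, the only step measured within one change is a number 0.50 log units lower from compound 1 to compound 3 (beyond the scatter), on a different core and with a different pair of groups, so it bears on the present change only as a guide to the size of step a heteroaryl swap produces here.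

Compound 4 `C[C@@H]1CC(=O)N(c2cnc(NCc3c(F)ccc4c3CCO4)n3cnnc23)C1` differs from compound 2 in one place: 4-methyl-2-oxopyrrolidin-1-yl in place of benzamido on an aromatic carbon. Among the compounds with values here, no measured pair covers a benzamido to 4-methyl-2-oxopyrrolidin-1-yl exchange, so the direction must be taken from the counted difference alone: one six-membered aromatic ring of carbon only leaves and one five-membered non-aromatic ring with 1 hetero atom enters, with one hydrogen-bond donor lost. A modest downward step is expected, a number 0.60 log units lower from compound 2 to compound 4 (beyond the scatter), of about the size seen from compound 1 to compound 3. Compound 4 is therefore estimated at 2.4, within 1.9 to 2.9.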

Compound 4, distribution coefficient: 1.8
The estimate for compound 4 lay 0.60 log units above the measured number; the whole stated range lies above it.
By their numbers in this assay, from the lowest: compound 4; then compound 3; then compounds 1 and 2 (each within the scatter of the next).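

At this aromatic carbon, para to a large group, the read-out in this assay changes markedly with the substituent: 4-methyl-2-oxopyrrolidin-1-yl in place of benzamido gives a number 1.20 log units lower from compound 2 to compound 4 (beyond the scatter) and is graded large. Going by these compounds alone, this is the only measured step at this position, and the only earlier step (a number 0.50 log units lower from compound 1 to compound 3 (beyond the scatter)), a heteroaryl exchange on a different core, is graded modest. The exchange removes one six-membered aromatic ring of carbon only and 1 hydrogen-bond donor, and it brings in one five-membered non-aromatic ring with 1 hetero atom and 1 defined stereocentre, but no measurement available ties the step to any one of these differences.

On these data alone, it remains open how the step divides between the aromatic ring and the amide hydrogen: an acetamido group keeps that hydrogen without the ring, while an N-methylbenzamido group keeps the ring without the hydrogen. As far as these compounds go, the contribution of the methyl group and its stereocentre also remains open, and the unsubstituted 2-oxopyrrolidin-1-yl group would be the direct comparison for compound 4.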